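A few compounds are considered here, and "the series" means these few. Any claim that something is new, unique, unknown or untested is made for them only; others in the source may bear on it.

Compounds measured in a functional assay on MGC-803 cells (Homo sapiens) for inhibition, read by MTT assay, with a stated time of 48 h; on this read-out higher numbers stand for weaker inhibition and lower numbers for stronger inhibition:
compound 1 `COc1ccc(Nc2nnc(Cl)c(Nc3cc(OC)c(OC)c(OC)c3)n2)cc1`: 19000 nM
compound 2 `COc1cc(Nc2nc(Nc3ccc(C)cc3)nnc2Cl)cc(OC)c1OC`: 19800 nM
compound 3 `COc1cc(Nc2nc(Nc3ccc(Br)cc3)nnc2Cl)cc(OC)c1OC`: 11400 nM

Compound 3 stands level with the other two compounds, since a 1.7-fold lower number from compound 1 to compound 3 (0.22 log units; within the scatter) and a 1.7-fold lower number from compound 2 to compound 3 (0.24 log units; within the scatter). The remaining measured step, a 1.0-fold higher number from compound 1 to compound 2 (0.02 log units; within the scatter), is no larger, so the three cannot be ranked in this assay.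

Compound 4 `COc1cc(Nc2nc(Nc3ccc4c(ccn4C)c3)nnc2Cl)cc(OC)c1OC` has not yet been measured. It keeps the shared core but carries 1-methyl-1H-indol-5-yl in place of 4-bromophenyl on a nitrogen on an aromatic ring. The measured steps bear on this change only indirectly, as each swaps methoxy, methyl or bromo on an aromatic carbon and none replaces the whole 4-bromophenyl. All of them stayed within the scatter, so no step beyond the scatter is expected in this assay, although the data give little support for so large a change and the range is kept wide. For compound 4 the expected value is 10000 nM, with an estimated range of 3000 nM to 25000 nM. The expected step is a 1.1-fold lower number from compound 3 to compound 4 (0.06 log units; within the scatter).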

Compound 4, half-maximal inhibitory concentration: 28100 nM
Beside the measured number, compound 4's estimate is 2.8-fold (0.45 log units) below it; measured number above the stated range.
By their numbers in this assay, from the lowest: compounds 3, 1, 2 and 4 (each within the scatter of the next, the first and the last beyond it).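

In this assay, 1-methyl-1H-indol-5-yl in place of 4-bromophenyl gives the first step beyond the scatter among these compounds, with a 2.5-fold higher number from compound 3 to compound 4 (0.39 log units; beyond the scatter), so a change on this nitrogen can move the number where the swaps of methoxy, methyl and bromo did not. The result depends on the group it is set against: with 1-methyl-1H-indol-5-yl in place of 4-methylphenyl there is a 1.4-fold higher number from compound 2 to compound 4 (0.15 log units; within the scatter), and in place of 4-methoxyphenyl there is a 1.5-fold higher number from compound 1 to compound 4 (0.17 log units; within the scatter), so the change is separated from the scatter only against 4-bromophenyl. Nothing available explains this step.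

On these data alone, it remains open how a 1H-indol-5-yl without the methyl, or a phenyl carrying an amine or a carboxylic acid, would behave on this nitrogen. Every compound shown also keeps the chloro on the shared core, so what that group contributes remains open too.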